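The source may hold more compounds than are shown below. What is called first, only, known or untested is meant among the compounds shown, and "the series" means these compounds.

Compound 1 `CCC[C@H](CCn1cncn1)c1ccccc1` is the simplest of the three measured compounds. In an ADME assay on HEp-2 cells (Homo sapiens) for cytotoxicity, read by MTT assay, with a stated time of 3 days (on this read-out higher numbers stand for lower toxicity in this test and lower numbers for higher toxicity in this test), compound 1 gives 58.4 ug/mL. Compound 2 `CCC[C@H](CCn1cncn1)c1ccc(C)cc1` carries methyl in place of hydrogen on an aromatic carbon relative to compound 1, and in this assay compound 2 gives 45.7 ug/mL; the step of a 1.3-fold lower number from compound 1 to compound 2 (0.11 log units; within the scatter). Compound 3 `c1ccc([C@@H](CCn2cncn2)C2CCCCC2)cc1` differs from compound 1 by cyclohexyl in place of propyl on a saturated chain carbon bound to an aromatic carbon and a saturated chain carbon, and in this assay compound 3 gives 21.8 ug/mL, which is the lowest of the three numbers; the step of a 2.7-fold lower number from compound 1 to compound 3 (0.43 log units; beyond the scatter). Compound 4 `Cc1ccc([C@@H](CCn2cncn2)C2CCCCC2)cc1` has not yet been measured. It differs from compound 3 by methyl in place of hydrogen on an aromatic carbon, the same change that separates compound 2 from compound 1, at a place described in the same words in both pairs. Since the earlier step of a 1.3-fold lower number from compound 1 to compound 2 (0.11 log units; within the scatter) stayed within the scatter, compound 4 is expected to sit close to compound 3 in this assay, and the expected step is a 1.3-fold lower number from compound 3 to compound 4 (0.11 log units; within the scatter), on the strength of that single earlier pair alone. On that basis compound 4 is estimated at 17 ug/mL in this assay, with a range from 9 ug/mL to 34 ug/mL.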

Compound 4, half-maximal cytotoxic concentration: 57.3 ug/mL
Compound 4: the middle estimate sits 3.4-fold (0.53 log units) below what was measured; the whole stated range lies below it.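

In this assay, methyl in place of hydrogen on an aromatic carbon gives a 2.6-fold higher number from compound 3 to compound 4 (0.42 log units; beyond the scatter), so on the cyclohexyl core the change does not repeat what it did on the propyl core: the same change on two cores in this assay, a 1.3-fold lower number (0.11 log units; within the scatter) from compound 1 to compound 2 and a 2.6-fold higher number (0.42 log units; beyond the scatter) from compound 3 to compound 4, 3.4-fold (0.53 log units) apart, beyond the scatter of two such steps. Read along the other edge, cyclohexyl in place of propyl gives a 1.3-fold higher number from compound 2 to compound 4 (0.10 log units; within the scatter), and this too departs from the earlier step: the same change on two cores in this assay, a 2.7-fold lower number (0.43 log units; beyond the scatter) from compound 1 to compound 3 and a 1.3-fold higher number (0.10 log units; within the scatter) from compound 2 to compound 4, 3.4-fold (0.53 log units) apart, beyond the scatter of two such steps. In these four compounds, then, the outcome of each change depends on the core that carries it, so neither step can simply be carried across, but a single set of four compounds in one cell assay gives no reason for this and no sign of how general it is.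

The compounds shown leave open whether an ethyl or a methoxy group on the same aromatic carbon would follow methyl on each core. They also leave open whether a cyclopentyl group or a longer chain in place of cyclohexyl would show the same dependence.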